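Carbamate in place of acetamide on the shared core

The compounds below may be only part of what the source reports. "The series", "measured", "known", "first", "only" and "open" are said of these compounds alone.

Three compounds of the series have numbers in a functional assay on WI-38 VA13 cells (Homo sapiens) for cytotoxicity; a higher number here means that more compound is needed for the effect, a lower number that less compound is needed. Compound 1 `O=C(Nc1ccc2nc(NC(=O)C3CCCCC3)sc2c1)c1c(F)cccc1C(F)(F)F` gives 0.032 ug/mL. Compound 2 `CC(=O)Nc1ccc2nc(NC(=O)C3CCCCC3)sc2c1` gives 2.7 ug/mL. Compound 3 `CC(=O)Nc1nc2ccc(NC(=O)c3c(Cl)cccc3Cl)cc2s1` gives 0.6 ug/mL. Compound 3 thus stands second highest of the three: compound 2 lies above it, by a gap beyond the scatter, and compound 1 lies well below it, also beyond the scatter. Among the compounds with values here, none of these pairs differs in a single place, so no step is drawn between them.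

Compound 4 `CC(C)OC(=O)Nc1nc2ccc(NC(=O)c3c(Cl)cccc3Cl)cc2s1` is not yet measured. It differs from compound 3 in one place: isopropoxy in place of methyl on a carbonyl carbon

Within the data shown here, no measured pair shows what this change does on this core. The change is small and keeps the amide-type linkage, so the step from compound 3 to compound 4 is expected to stay within the usual scatter, in no particular direction: no change at the digits printed from compound 3 to compound 4 (within the scatter) is the estimated step. Compound 4 is therefore expected to give about 0.6 ug/mL, with a range from 0.2 ug/mL to 2 ug/mL in this assay.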

Compound 4, half-maximal effective concentration: 0.0026 ug/mL
Estimate against measurement, compound 4: 230-fold (2.36 log units) above; measured number below the stated range.
By their numbers in this assay, from the lowest: compound 4; then compound 1; then compound 3; then compound 2.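

The acyl group on this amide-type nitrogen strongly affects the number: in this assay, isopropoxy in place of methyl on a carbonyl carbon gives a 230-fold lower number from compound 3 to compound 4 (2.36 log units; beyond the scatter), a large step well beyond the scatter. Within the data shown here, the earlier compounds offered no pair differing in one place, so this is the first reading of a single change. It shows that going from acetamido to (isopropoxycarbonyl)amino, with the rest of the structure kept, is enough to move the number this far. No measurement shown here bears on why the step is so large.

The compounds shown do not separate the carbamate oxygen from the branched isopropyl carbons, as neither a methoxycarbonyl group nor an isobutyryl group stands on this nitrogen. Going by these compounds, whether the step holds when the other amide of compound 3 is replaced also stays open.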